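The source may report more compounds than this note shows. Statements on the series, on what has been measured and on what is new or still open speak of the compounds shown alone.

Three compounds have been measured in an assay on isolated protein for inhibition of aldehyde dehydrogenase 1A1 (Homo sapiens), read by spectrophotometry, tested at 10 uM; a lower number here means less inhibition, a higher number more inhibition at the concentration tested (going by the name of the read-out):

compound 1, `CCn1c(CN2CCN(C(=O)C3CC3)CC2)nc2ccccc21`: 20.8%
compound 2, `O=C(C1CC1)N1CCN(Cc2nc3ccccc3n2Cc2ccccc2)CC1`: 23.9%
compound 3, `O=C(C1CC1)N1CCN(Cc2nc3ccccc3n2CC2CC2)CC1`: 21.2%

All three share the same core and differ only in the group on a saturated chain carbon bound to an aromatic nitrogen. Their numbers lie close together: the step of a number 0.4 percentage points higher from compound 1 to compound 3 (within the scatter) and the step of a number 2.7 percentage points lower from compound 2 to compound 3 (within the scatter) are both within the usual scatter, so compound 3 cannot be set apart from either neighbour on these figures.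

Compound 4, `O=C(C1CC1)N1CCN(Cc2nc3ccccc3n2CC2CCCC2)CC1`, has not been measured. It differs from compound 3 in one place: cyclopentyl in place of cyclopropyl on a saturated chain carbon bound to an aromatic nitrogen.

Among the measured compounds shown here, every measured step so far swaps the group at this very position. Methyl to phenyl, a number 3.1 percentage points higher from compound 1 to compound 2 (within the scatter), methyl to cyclopropyl, a number 0.4 percentage points higher from compound 1 to compound 3 (within the scatter), and phenyl to cyclopropyl, a number 2.7 percentage points lower from compound 2 to compound 3 (within the scatter), all stayed within the scatter. Three such swaps, from a small group to a larger ring and back, left this assay almost unchanged. The expected result is therefore that the step of a number 0.2 percentage points lower from compound 3 to compound 4 (within the scatter) will also fall within the scatter. For compound 4 the estimate is 21%, with a range from 12% to 31%.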

Compound 4, a percentage reported as inhibition, at one concentration (the size of the read-out at that concentration, not a potency): 44.5%
Compound 4: middle estimate off by 23.5 percentage points, on the low side, outside the stated range (above it).
By their numbers in this assay, from the lowest: compounds 1, 3 and 2 (each within the scatter of the next); then compound 4.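

In this assay, among the compounds shown here, this position proves less indifferent than the earlier compounds suggested: cyclopentyl in place of cyclopropyl gives a number 23.3 percentage points higher from compound 3 to compound 4 (beyond the scatter) and cyclopentyl in place of phenyl gives a number 20.6 percentage points higher from compound 2 to compound 4 (beyond the scatter) while cyclopentyl in place of methyl gives a number 23.7 percentage points higher from compound 1 to compound 4 (beyond the scatter) on the same saturated chain carbon bound to an aromatic nitrogen. A ring at this place is not enough on its own: compound 2 with phenyl and compound 3 with cyclopropyl both carry one, yet both remain within the scatter of compound 1 with its methyl, and only compound 4 stands apart. Nothing available here explains why cyclopentyl behaves differently from the other three groups.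

The compounds shown leave open whether this rise is particular to cyclopentyl or is shared by cyclobutyl, cyclohexyl or an open chain such as pentyl at the same place. From the compounds shown here alone, each figure is also a reading at one concentration, so how far compound 4 differs from the others in potency remains open.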